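The source may hold more compounds than are shown below. What is called first, only, known or untested is meant among the compounds shown, and "the series" means these compounds.

Measured so far:
- Compound 1, `Cn1ccc2ccc(-c3cc(Nc4ccccc4S(=O)(=O)NCC4CCOCC4)cc4nccnc34)cc21`: 2 ug/mL
- Compound 2, `CC(=O)N1CCC(NC(=O)c2ccncc2Nc2cc(-c3ccc4ccn(C)c4c3)c3nccnc3c2)CC1`: 213 ug/mL

Of the compounds shown here, two have been measured in a physicochemical assay for solubility, read by spectrophotometry, measured as kinetic solubility, at pH 8, tested at 500 uM; on this read-out lower numbers stand for lower solubility and higher numbers for higher solubility. Compound 1 gives 2 ug/mL, while compound 2 gives 213 ug/mL, the higher of the two numbers by a gap that lies well beyond the scatter of this assay. Compound 2 is thus the better-dissolving of the pair.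

Compound 3, `CC(=O)N1CC(CNC(=O)c2ccncc2Nc2cc(-c3ccc4ccn(C)c4c3)c3nccnc3c2)C1`, has not yet been measured. It keeps the whole of compound 2 apart from one group on an amide-type nitrogen whose other neighbour is a carbonyl carbon: (1-acetylazetidin-3-yl)methyl in place of 1-acetylpiperidin-4-yl on an amide-type nitrogen. Both groups carry one ring with one hetero atom, one acceptor and no donor, so the overall make-up barely shifts.

Because compound 2 gives 213 ug/mL, the expected step in this assay is a 1.2-fold lower number from compound 2 to compound 3 (0.07 log units; within the scatter), a change of no clear direction within the scatter. Compound 3 is therefore estimated at 180 ug/mL, with a range from 70 ug/mL to 400 ug/mL.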

Compound 3, solubility: 252 ug/mL
Estimate against measurement, compound 3: 1.4-fold (0.15 log units) below; measured number inside the range.
By their numbers in this assay, from the lowest: compound 1; then compounds 2 and 3 (each within the scatter of the next).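

In this assay the swap of 1-acetylpiperidin-4-yl for (1-acetylazetidin-3-yl)methyl on the amide-type nitrogen gives a 1.2-fold higher number from compound 2 to compound 3 (0.07 log units; within the scatter) and so leaves the two compounds indistinguishable. At this position, then, a four-membered non-aromatic ring can stand in for a six-membered one without a readable step in this measurement. Nothing measured here points to a reason for this result.

Going by these compounds alone, this pair covers only two neutral acetylated rings, so how a free amine, a carboxylic acid or a longer chain on this nitrogen would read in this assay remains open. Compound 1 differs from compound 2 in more than one place, so the large gap between them cannot yet be traced to any single part of the structure.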